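The compounds below may be only part of what the source reports. "The series", "measured", "known", "first", "only" and "open" are said of these compounds alone.

Going by the values given here, compound 2, `O=C(NCCCCc1ccccc1)n1c(=O)oc2ccc(F)cc21`, is the weaker of the two compounds measured so far in an assay on HEK293 cells for inhibition of acid ceramidase (Homo sapiens), with a stated time of 10 min; a lower number here means a stronger inhibitor, a higher number a weaker inhibitor: compound 2 gives 12 nM, whereas compound 1, `O=C(NCCCCc1ccccc1)n1c(=O)oc2ccc([N+](=O)[O-])cc21`, gives 3 nM. Among the compounds with values here, the one step connecting them, a 4.0-fold higher number from compound 1 to compound 2 (0.60 log units; beyond the scatter), is the only measured change at the substituted aromatic carbon of the shared core, and it shows that swapping the group at that position moves the number by a modest, clearly resolvable amount.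

Compound 3, `COc1ccc(-c2ccc3oc(=O)n(C(=O)NCCCCc4ccccc4)c3c2)cc1`, carries the change (4-methoxyphenyl in place of fluoro on an aromatic carbon). The step from compound 1 to compound 2 bears on this only indirectly: it concerns a small group replaced by another small group, while here the fluoro gives way to a much larger 4-methoxyphenyl, a change for which no measured comparison exists. The direction therefore cannot be read from the data, and a shift of about the size seen between compound 1 and compound 2, in either direction, is as plausible as none beyond the scatter.

The estimate for compound 3 in this assay is accordingly 15 nM, with a range of 4 nM to 60 nM, meaning an expected step of a 1.3-fold higher number from compound 2 to compound 3 (0.10 log units; within the scatter).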

Compound 3, half-maximal inhibitory concentration: 67 nM
Compound 3: the middle estimate sits 4.5-fold (0.65 log units) below what was measured; measured number above the stated range.
By their numbers in this assay, from the lowest: compound 1; then compound 2; then compound 3.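

In this assay, going by these compounds alone, the first large group at this aromatic carbon, 4-methoxyphenyl with its 8 heavy atoms and aromatic ring in place of the single fluorine atom, gives a 5.6-fold higher number from compound 2 to compound 3 (0.75 log units; beyond the scatter) and, measured against the nitro group, a 22-fold higher number from compound 1 to compound 3 (1.35 log units; beyond the scatter) as the widest step in the set. With every step printed as beyond the scatter, the three groups separate into a clear order of nitro, then fluoro, then 4-methoxyphenyl, so the position responds to more than a swap between small groups, yet compound 3 still gives 67 nM and the large group does not abolish inhibition. No supporting measurement is available to explain why the numbers shift at this position.

The compounds shown do not separate the contribution of the added aromatic ring from that of its methoxy group, which a plain phenyl at the same carbon would address. They also leave open how an amine or a carboxylic acid would fare at this position, and whether a longer chain in place of the side chain shared by all three compounds would change the order seen here.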